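The source may hold more compounds than are shown below. What is called first, only, known or untested is meant among the compounds shown, and "the series" means these compounds.

Compound 1 `CN(C)c1ccc(C2CC(c3ccc(-n4cncn4)cc3)=NN2S(=O)(=O)c2ccc(F)cc2)cc1`: 24.1% in a functional assay on HCC1806 cells (Homo sapiens) for inhibition, read by sulforhodamine B assay, tested at 10 uM; on this read-out higher numbers stand for more inhibition at the one concentration tested (going by the name of the read-out) and lower numbers for less inhibition
Compound 2 `CN(C)c1ccc(C2CC(c3ccc(-n4cncn4)cc3)=NN2S(=O)(=O)c2ccc(C(F)(F)F)cc2)cc1`: 37%
Compound 3 `CN(C)c1ccc(C2CC(c3ccc(-n4cncn4)cc3)=NN2S(=O)(=O)c2ccc(C#N)cc2)cc1`: 33.1%

On these numbers compound 3 is set apart from neither of the other two: a number 9 percentage points higher from compound 1 to compound 3 (within the scatter) and a number 3.9 percentage points lower from compound 2 to compound 3 (within the scatter) both lie within the scatter. Among the measured compounds shown here, the one step beyond the scatter is a number 12.9 percentage points higher from compound 1 to compound 2 (beyond the scatter), and even that is modest. Compound 4 `CN(C)c1ccc(C2CC(c3ccc(-n4cncn4)cc3)=NN2S(=O)(=O)c2ccc(OC(F)(F)F)cc2)cc1` differs from compound 3 in one respect: trifluoromethoxy in place of cyano on an aromatic carbon. For the measured compounds named here, no measured pair carries this exact change; the nearest guide is the trifluoromethyl step, a number 12.9 percentage points higher from compound 1 to compound 2 (beyond the scatter), while every step touching compound 3 stayed within the scatter. Compound 4 is therefore expected to give a number close to that of compound 3, with a number 2.9 percentage points higher from compound 3 to compound 4 (within the scatter) as the expected step. The estimate for compound 4 in this assay is 36%, within 22% to 50%.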

Compound 4, a percentage reported as inhibition, at one concentration (the size of the read-out at that concentration, not a potency): 25.2%
Beside the measured number, compound 4's estimate is 10.8 percentage points above it; measured number inside the range.
By their numbers in this assay, from the lowest: compounds 1, 4, 3 and 2 (each within the scatter of the next, the first and the last beyond it).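

The trifluoromethoxy group does not track trifluoromethyl at this position: in this assay there is a number 11.8 percentage points lower from compound 2 to compound 4 (beyond the scatter), a modest step showing that these two groups cannot be treated as interchangeable here. Against the other two groups, the readings show a number 1.1 percentage points higher from compound 1 to compound 4 (within the scatter) and a number 7.9 percentage points lower from compound 3 to compound 4 (within the scatter), so neither step separates compound 4 from compound 1 or compound 3. Nothing available accounts for the step away from trifluoromethyl.

On these data alone, what remains open is how an amine, a carboxylic acid or a methoxy group would read at this position. With only a single concentration, the potency of these compounds also remains open.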